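Lengthening the hydroxycarbamoyl chain towards compound 4

The source may report more compounds than this note shows. Statements on the series, on what has been measured and on what is new or still open speak of the compounds shown alone.

Measured so far in a functional assay on HeLa cells (Homo sapiens) for inhibition, read by MTT assay, with a stated time of 72 h; on this read-out higher numbers stand for weaker inhibition and lower numbers for stronger inhibition (half-maximal inhibitory concentrations):
- compound 1 `Nc1nc2cc(-c3nn(CCC(=O)NO)c4ncnc(N)c34)ccc2o1` gives > 150000 nM (a limit)
- compound 2 `Nc1nc2cc(-c3nn(CCCCC(=O)NO)c4ncnc(N)c34)ccc2o1` gives 32200 nM
- compound 3 `Nc1nc2cc(-c3nn(CC(=O)NO)c4ncnc(N)c34)ccc2o1` gives > 150000 nM (a limit)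
- compound 4 `Nc1nc2cc(-c3nn(CCCCCCC(=O)NO)c4ncnc(N)c34)ccc2o1` is not yet measured

Compound 3 has only a limit and no number: > 150000 nM in this assay, which is the limit of > 150000 nM in this assay, at which 2 of the 3 values shown sit. The change to compound 4 is 5-(hydroxycarbamoyl)pentyl in place of hydroxycarbamoyl on a saturated chain carbon bound to an aromatic nitrogen, with 5-(hydroxycarbamoyl)pentyl in place of hydroxycarbamoyl on a saturated chain carbon bound to an aromatic nitrogen.

Two measured chain changes bear on this, an at least 4.6-fold lower number from compound 1 to compound 2 (0.66 log units; beyond the scatter) and an at least 4.6-fold higher number from compound 2 to compound 3 (0.66 log units; beyond the scatter), both beyond the scatter. A third, a step that the two limits leave unreadable from compound 1 to compound 3, cannot be read. Within the data shown here, compound 2 has the longest chain measured and is the only one with a number. Going by compound 2 and an at least 4.6-fold higher number from compound 2 to compound 3 (0.66 log units; beyond the scatter), a lower number is expected in this assay for the still longer chain, an estimated at least 30-fold lower number from compound 3 to compound 4 (1.47 log units; beyond the scatter). For compound 4 the estimate is 5000 nM, with an expected range of 1000 nM to 25000 nM.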

Compound 4, half-maximal inhibitory concentration: 6410 nM
Compound 4: the middle estimate sits 1.3-fold (0.11 log units) below what was measured; the measured number falls inside the stated range.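

Among these compounds, the position keeps responding as the chain grows beyond the longest earlier one: in this assay there is a 5.0-fold lower number from compound 2 to compound 4 (0.70 log units; beyond the scatter), the only step here between two actual numbers. Against the shorter chains, the gaps are an at least 23-fold lower number from compound 3 to compound 4 (1.36 log units; beyond the scatter) and an at least 23-fold lower number from compound 1 to compound 4 (1.36 log units; beyond the scatter), and both are bounds only. Compound 1 and compound 3 each give a limit, not a number: the limit of > 150000 nM in this assay, at which 2 of the 4 values shown sit.

Going by these compounds, whether a longer chain than 5-(hydroxycarbamoyl)pentyl would lower the number further remains open. So does what a carboxylic acid in place of the hydroxycarbamoyl end would give at the same chain length.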